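Inverting One Ring Centre in a Rigid Glutamate Mimic

This account rests on a few compounds, and the source may have more. Where it says the series, first, only, none or still open, it means among the compounds named here.

Compound 1 `CO[C@@H]1C[C@@H]2[C@H]([C@]1(N)C(=O)O)[C@@]2(F)C(=O)O` is the smallest member of this set, carrying a methoxy group on its bicyclic core. In an assay on CHO cells for binding affinity to metabotropic glutamate receptor 2 (Rattus norvegicus) (on this read-out higher numbers stand for weaker inhibition and lower numbers for stronger inhibition), compound 1 gives 39.2 nM, the highest number of the three measured compounds. Compound 2 `N[C@]1(C(=O)O)[C@H]2[C@@H](C[C@H]1OCc1ccc(Cl)cc1Cl)[C@]2(F)C(=O)O` gives 3.89 nM and compound 3 `N[C@]1(C(=O)O)[C@H]2[C@@H](C[C@H]1OCc1cc(Cl)ccc1Cl)[C@]2(F)C(=O)O` gives 11.8 nM. The measured steps all concern what hangs from the oxygen: a 10-fold lower number from compound 1 to compound 2 (1.00 log units; beyond the scatter) and a 3.3-fold lower number from compound 1 to compound 3 (0.52 log units; beyond the scatter), while a 3.0-fold higher number from compound 2 to compound 3 (0.48 log units; beyond the scatter).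

Compound 4 `CO[C@H]1C[C@@H]2[C@H]([C@]1(N)C(=O)O)[C@@]2(F)C(=O)O` is a different kind of change. Relative to compound 1, (the two compounds have the same atoms and bonds and differ only in configuration as drawn: 1 of 5 stereo elements differ; a stereocentre at a saturated ring carbon is drawn R in compound 1 and S in compound 4). Within the data shown here, no measured step alters configuration; every one of them replaces hydrogen with a dichlorophenyl group or swaps one such group for another, so none bears directly on this inversion. Without a comparable step to lean on, the expectation is only loosely anchored: a moderately higher number is estimated, a 3.1-fold higher number from compound 1 to compound 4 (0.49 log units; beyond the scatter), with a wide range. Compound 4 is therefore expected to give about 120 nM, somewhere between 25 nM and 700 nM.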

Compound 4, inhibition constant: 190 nM
Beside the measured number, compound 4's estimate is 1.6-fold (0.20 log units) below it; measured number inside the range.
By their numbers in this assay, from the lowest: compound 2; then compound 3; then compound 1; then compound 4.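

Inverting one saturated ring carbon, with no atom added or removed, gives a 4.8-fold higher number from compound 1 to compound 4 (0.69 log units; beyond the scatter) in this assay. Among these compounds, the arrangement in space at this carbon therefore matters on its own, something the earlier steps could not show, as each of them changed what hangs from the oxygen and kept the configuration the same. The shift can be assigned to this one centre because nothing else separates the pair: the fact that compounds 1 and 4 differ only in the configuration as drawn

The compounds shown leave open whether the same inversion would move the number to a similar extent with the larger groups on the oxygen of compound 2 and compound 3. They also do not tell how an amine or a longer chain in place of the methoxy group would fare in either configuration at this carbon.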